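A few compounds are considered here, and "the series" means these few. Any claim that something is new, unique, unknown or untested is made for them only; others in the source may bear on it.

The series shares one core; compound 1 is `CCCCCc1cc2c(=O)n(CCCSc3nc(-c4cc(OC)c(OC)c(OC)c4)c(C#N)c(=O)[nH]3)cnc2s1`, compound 2 is `CCCCCCc1cc2c(=O)n(CCCSc3nc(-c4cc(OC)c(OC)c(OC)c4)c(C#N)c(=O)[nH]3)cnc2s1` and compound 3 is `CCCCCCCc1cc2c(=O)n(CCCSc3nc(-c4cc(OC)c(OC)c(OC)c4)c(C#N)c(=O)[nH]3)cnc2s1`. In an ADME assay on A549 cells (Homo sapiens) for inhibition, read by MTT assay (on this read-out higher numbers stand for weaker inhibition of growth and lower numbers for stronger inhibition of growth), compound 1 gives only a limit, > 100 ug/mL. In this assay compound 2 gives 90.2 ug/mL. In this assay compound 3 gives 90.5 ug/mL, and so stands together with compound 2, the two numbers being within the scatter. The steps measured so far are an at least 1.1-fold lower number from compound 1 to compound 2 (0.04 log units; that floor lies within the scatter), an at least 1.1-fold lower number from compound 1 to compound 3 (0.04 log units; that floor lies within the scatter) and a 1.0-fold higher number from compound 2 to compound 3 (0.00 log units; within the scatter); the floor of the two steps from compound 1 comes from the limit of > 100 ug/mL in this assay, at which 1 of the 3 values shown sits. Compound 4 is `CCCc1cc2c(=O)n(CCCSc3nc(-c4cc(OC)c(OC)c(OC)c4)c(C#N)c(=O)[nH]3)cnc2s1`. It differs from compound 3 by hydrogen in place of butyl on a saturated chain carbon, three bonds along the chain from an aromatic carbon, a change running opposite to the lengthenings measured and cutting deeper into the chain than any of them. Because a 1.0-fold higher number from compound 2 to compound 3 (0.00 log units; within the scatter) and an at least 1.1-fold lower number from compound 1 to compound 3 (0.04 log units; that floor lies within the scatter) lay within the scatter, the step to compound 4 is expected to be a 1.0-fold lower number from compound 3 to compound 4 (0.00 log units; within the scatter), with no direction beyond the scatter. For compound 4 the estimate in this assay is 90 ug/mL, within 40 ug/mL to 200 ug/mL.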

Compound 4, concentration for 50% growth inhibition: > 100 ug/mL
Compound 4: a limit, no number; the forecaster's own chance of this, stated with the estimate: 35%; middle value at least 1.1-fold (0.04 log units) away from the limit.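

In this assay, hydrogen in place of butyl at this position gives an at least 1.1-fold higher number from compound 3 to compound 4 (0.04 log units; that floor lies within the scatter), and hydrogen in place of propyl gives an at least 1.1-fold higher number from compound 2 to compound 4 (0.04 log units; that floor lies within the scatter). Even this deeper cut into the chain therefore shows no step beyond the scatter, and compound 4, like compound 1, gives only a limit, so the step between those two cannot be read. Both readable steps remain floors rather than measured sizes, because the result for compound 4 is a limit: the limit of > 100 ug/mL in this assay, at which 2 of the 4 values shown sit.

Still open, on these data alone, is whether a chain longer than heptyl, such as decyl, or a propyl chain ending in an amine or a carboxylic acid would move growth inhibition at this position. The compounds shown also leave open whether any change here can give a step beyond the scatter.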